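Swapping a Methyl for an Ethoxy on the Benzyl Ring

A few compounds are considered here, and "the series" means these few. Any claim that something is new, unique, unknown or untested is made for them only; others in the source may bear on it.

Measured compounds:
Compound 1, `FC(F)(F)Oc1ccccc1Nc1ncnn1-c1cccc(Cl)c1Cl`, 5500 nM
Compound 2, `Cc1ccccc1CNc1ncnn1-c1cccc(Cl)c1Cl`, 200 nM
Compound 3, `COc1ccc(CNc2ncnn2-c2cccc(Cl)c2Cl)cc1`, 10500 nM

All three share one core and were tested in a functional assay for antagonist activity at P2X purinoceptor 7 (Rattus norvegicus), read by FLIPR and calcium flux; on this read-out higher numbers stand for weaker inhibition and lower numbers for stronger inhibition. Compound 2 stands lowest of the three numbers, which here means the strongest inhibition; compound 1 gives a number that lies well beyond the scatter above it, and compound 3 gives the furthest one, also beyond the scatter. Compound 4, `CCOc1ccccc1CNc1ncnn1-c1cccc(Cl)c1Cl`, has not yet been measured. It differs from compound 2 in a single place: ethoxy in place of methyl on an aromatic carbon. The ethoxy group takes the spot that the methyl held, on the six-membered aromatic ring of carbon only, ortho to a large group. Among the compounds with values here, no measured pair shows this exact exchange, so the direction of the step is open. Since compound 3, which carries an oxygen-linked group elsewhere on that ring, sits far above compound 2, some loss seems more likely than a gain. Compound 4 is therefore expected to give about 800 nM in this assay, with a range from 200 nM to 4000 nM, a step of a 4.0-fold higher number from compound 2 to compound 4 (0.60 log units; beyond the scatter) that is expected to exceed the scatter.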

Compound 4, half-maximal inhibitory concentration: 490 nM
Estimate against measurement, compound 4: 1.6-fold (0.21 log units) above; low and high end bracket the measured number.
By their numbers in this assay, from the lowest: compound 2; then compound 4; then compounds 1 and 3 (each within the scatter of the next).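

In this assay, within the data shown here, ethoxy in place of methyl on this aromatic carbon gives a 2.5-fold higher number from compound 2 to compound 4 (0.39 log units; beyond the scatter), the first direct reading of a change at this place. The step is modest but beyond the scatter, and its direction favours the methyl. So this place accepts the ethoxy group, with its extra heavy atoms and its hydrogen-bond acceptor, at a modest cost in inhibition rather than a complete loss, though nothing at hand says why the step runs this way.

Going by these compounds, with only methyl and ethoxy seen at this place, it remains open whether methoxy, which would show the effect of the oxygen with a shorter chain, or a longer chain such as propoxy would give a lower or a higher number. On these data alone, how an amine or a chlorine atom would behave on this aromatic carbon also remains open.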